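Compound 4: 3,5-dibromophenyl on the series

The compounds below may be only part of what the source reports. "The series", "measured", "known", "first", "only" and "open" are said of these compounds alone.

Measured in a functional assay on C8166 cells (Homo sapiens) for cytotoxicity, read by MTT assay; a lower number here means that less compound is tolerated, a higher number that more compound is tolerated:
- compound 1 `Cc1cc(S(N)(=O)=O)ccc1NC(=O)COc1ccc(Cl)cc1NC(=O)c1cccc(F)c1`: 243000 nM
- compound 2 `Cc1cc(S(N)(=O)=O)ccc1NC(=O)COc1ccc(Cl)cc1NC(=O)c1ccc(Cl)cc1Cl`: 61100 nM
- compound 3 `Cc1cc(S(N)(=O)=O)ccc1NC(=O)COc1ccc(Cl)cc1NC(=O)c1cc(Cl)cc(Cl)c1`: 72400 nM

Compound 3 stands level with compound 2, a 1.2-fold higher number from compound 2 to compound 3 (0.07 log units; within the scatter), and both lie under compound 1. Compound 4 `Cc1cc(S(N)(=O)=O)ccc1NC(=O)COc1ccc(Cl)cc1NC(=O)c1cc(Br)cc(Br)c1` carries 3,5-dibromophenyl in place of 3,5-dichlorophenyl on a carbonyl carbon. Among the compounds with values here, no measured step covers this exact exchange. The closest evidence is modest: a 4.0-fold lower number from compound 1 to compound 2 (0.60 log units; beyond the scatter) and a 3.4-fold lower number from compound 1 to compound 3 (0.53 log units; beyond the scatter). Moving between the two dichlorophenyl groups gave a 1.2-fold higher number from compound 2 to compound 3 (0.07 log units; within the scatter), so no step beyond the scatter is expected in this assay, at most a slight drift to a lower number. The estimated step is a 1.3-fold lower number from compound 3 to compound 4 (0.11 log units; within the scatter) as the middle expectation. For compound 4 the estimated value is 56000 nM with an expected range from 25000 nM to 125000 nM.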

Compound 4, half-maximal cytotoxic concentration: 89700 nM
For compound 4 the middle estimate is 1.6-fold (0.20 log units) below the measured one, within the range that was stated.
By their numbers in this assay, from the lowest: compounds 2, 3 and 4 (each within the scatter of the next); then compound 1.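

At this place on a carbonyl carbon, 3,5-dibromophenyl reads level with 3,5-dichlorophenyl in this assay with a 1.2-fold higher number from compound 3 to compound 4 (0.09 log units; within the scatter) and level with 2,4-dichlorophenyl with a 1.5-fold higher number from compound 2 to compound 4 (0.17 log units; within the scatter) as the second reading. The gap to 3-fluorophenyl holds with bromine in place of chlorine, at a 2.7-fold lower number from compound 1 to compound 4 (0.43 log units; beyond the scatter) and so all three dihalophenyl compounds lie under compound 1. No supporting data bear on these readings.

Going by these compounds, whether 3-chlorophenyl or 3-bromophenyl would read with compound 1 or with the dihalophenyl compounds stays open. Also open, on these data alone, is how a phenyl carrying an amine or a carboxylic acid would read here.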